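Ester chain length in a small displacement series

The source may hold more compounds than are shown below. What is called first, only, known or untested is meant among the compounds shown, and "the series" means these compounds.

Compound 1 `CCCOC(=O)C1=C(C)NC(=S)NC1c1ccco1`: 1%
Compound 2 `CC1=C(C(=O)OCC(C)C)C(c2ccco2)NC(=S)N1`: 7%
Compound 3 `COC(=O)C1=C(C)N(C)C(=O)NC1c1ccsc1`: 24%

In an assay on membranes from CHO cells for displacement of a labelled ligand from adenosine receptor A1 (Homo sapiens), read by scintillation counting, with a stated time of 60 min, tested at 1 uM (on this read-out higher numbers stand for more inhibition at the one concentration tested (going by the name of the read-out) and lower numbers for less inhibition), compound 1 gives 1%, compound 2 gives 7% and compound 3 gives 24%. The step from compound 1 to compound 2 is a number 6 percentage points higher from compound 1 to compound 2 (within the scatter); the change behind it is methyl in place of hydrogen on a saturated chain carbon bound to two saturated chain carbons. Compound 3 rests on a different core, and the difference between the two cores is not broken down here.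

Compound 4 `CCOC(=O)C1=C(C)N(C)C(=O)NC1c1ccsc1` has not yet been measured in this assay. It differs from compound 3 by methyl in place of hydrogen on a saturated chain carbon bound to an oxygen next to a carbonyl group. This is the same kind of change as that from compound 1 to compound 2, though the place differs: there the methyl enters on a saturated chain carbon bound to two saturated chain carbons, here on a saturated chain carbon bound to an oxygen next to a carbonyl group. Since one added methyl in the earlier pair gave only a number 6 percentage points higher from compound 1 to compound 2 (within the scatter), a step of about the same size is expected here, a number 3 percentage points higher from compound 3 to compound 4 (within the scatter). Compound 4 is therefore estimated at 27%, between 12% and 42%.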

Compound 4, a percentage reported as inhibition, at one concentration (the size of the read-out at that concentration, not a potency): 32%
Compound 4: the middle estimate sits 5 percentage points below what was measured, within the range that was stated.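

In this assay, methyl in place of hydrogen on a saturated chain carbon bound to an oxygen next to a carbonyl group gives a number 8 percentage points higher from compound 3 to compound 4 (within the scatter). Set beside the earlier step, the change reads alike on the two cores: the same change on two cores in this assay, a number 6 percentage points higher (within the scatter) from compound 1 to compound 2 and a number 8 percentage points higher (within the scatter) from compound 3 to compound 4, 2 percentage points apart, within the scatter of two such steps. Within the data shown here, this shows only that the two steps cannot be told apart in this one read-out; as each lies within the scatter, it does not show that the methyl has a real effect on either core, and two pairs, with the methyl at different places, make no rule for the series.

The compounds shown leave open how a longer chain in place of the ethyl would read on the core of compound 3. They also leave open whether an amine or a carboxylic acid at that place would read any differently.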